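Notes on the acyl change from compound 2 to compound 4

The compounds below may be only part of what the source reports. "The series", "measured", "known", "first", "only" and "open" are said of these compounds alone.

Measured compounds:
compound 1 `C/C=C/C(=O)N(Cc1cc(OC)c(OC)c(OC)c1)c1ccc(OC)c(O)c1`: 6150 nM
compound 2 `CCC/C=C/C(=O)N(Cc1ccc(OC)c(O)c1)c1cc(OC)c(OC)c(OC)c1`: 70 nM
compound 3 `C/C=C/C(=O)N(Cc1cccc(O)c1)c1cc(OC)c(OC)c(OC)c1`: 14100 nM

All three were run in a functional assay on MGC-803 cells (Homo sapiens) for inhibition, read by MTT assay, with a stated time of 48 h; a lower number here means a stronger inhibitor, a higher number a weaker inhibitor. Compound 2 stands at the lowest of the three numbers; compound 1 sits at a clearly higher number and compound 3 higher still, both gaps beyond the usual scatter. Within the data shown here, neither of those two differs from compound 2 in one place only, so no single-change step is available within the measured set.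

Compound 4 `COc1ccc(CN(C(=O)C2CC2)c2cc(OC)c(OC)c(OC)c2)cc1O` is not yet measured. It differs from compound 2 in one place: cyclopropyl in place of pent-1-en-1-yl on a carbonyl carbon. The chain with its double bond outside aromatic rings is gone, and a three-membered ring of carbon only sits on the carbonyl carbon instead.

Among the measured compounds shown here, nothing among the measured compounds isolates this change, so the expectation rests on compound 2 alone and carries a wide range. The step is expected to go toward a higher number, beyond the scatter, as an 11-fold higher number from compound 2 to compound 4 (1.06 log units; beyond the scatter). Compound 4 is estimated at 800 nM, with a range from 120 nM to 6000 nM.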

Compound 4, half-maximal inhibitory concentration: 59 nM
The estimate for compound 4 lay 14-fold (1.13 log units) above the measured number, outside the stated range (below it).
By their numbers in this assay, from the lowest: compounds 4 and 2 (each within the scatter of the next); then compound 1; then compound 3.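

In this assay, exchanging pent-1-en-1-yl for cyclopropyl on the carbonyl carbon leaves the read-out unmoved: the step is a 1.2-fold lower number from compound 2 to compound 4 (0.07 log units; within the scatter). Among these compounds, this is the first single-change reading, and it shows that neither the open chain nor its double bond outside aromatic rings is required at this place for a number at this level. No measured evidence accounts for the two groups reading alike.

From the compounds shown here alone, whether this tolerance extends to a phenyl ring, a cyclohexyl ring or a dimethylamino group on the carbonyl carbon remains open. Compound 1 and compound 3 each differ from compound 2 in more than one place, so what drives their higher numbers also remains unresolved.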